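The source may hold more compounds than are shown below. What is called first, only, known or untested is meant among the compounds shown, and "the series" means these compounds.

The measured compounds, all in an assay on Sf9 cells for inhibition of protein deacetylase HDAC6 (Homo sapiens), read by fluorescence, with a stated time of 2 h; a lower number here means a stronger inhibitor, a higher number a weaker inhibitor:

Compound 1 `O=C(O)CCCCCOc1ccc2cc1COC/C=C/COCc1cccc(c1)-c1ccnc(n1)N2` gives 45000 nM.
Compound 2 `O=C(NO)c1ccc(OCCOc2ccc3cc2COC/C=C/COCc2cccc(c2)-c2ccnc(n2)N3)cc1` gives 66 nM.
Compound 3 `O=C(O)CCCCCCC(=O)Nc1ccc(NCCOc2ccc3cc2COC/C=C/COCc2cccc(c2)-c2ccnc(n2)N3)cc1` gives 2600 nM.

Within this set, compound 2 stands lowest in this assay; compound 3 is nearest to it, and compound 1 furthest, both beyond the scatter. The next compound, compound 4 `O=C(O)CCCCCCOc1ccc2cc1COC/C=C/COCc1cccc(c1)-c1ccnc(n1)N2`, departs from compound 2 by 4-carboxybutyl in place of 4-(hydroxycarbamoyl)phenoxy on a saturated chain carbon, two bonds along the chain from an oxygen on an aromatic ring. In effect a hydroxamic acid on a ring is replaced by a carboxylic acid on a chain, so compound 4 carries the same acid type as compound 1 on a chain one carbon longer.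

Going by the values given here, the one measured step that bears on this is a 680-fold lower number from compound 1 to compound 2 (2.83 log units; beyond the scatter), which runs in the opposite direction: from a chain acid to the hydroxamic acid. Reversing it suggests a large rise in the number for compound 4 in this assay, of roughly the same size, since compound 1 differs from compound 4 only in chain length and no step between the two is available. Compound 3, with an amide-linked chain acid, lies well above compound 2 as well, in keeping with that direction.

Compound 4 is therefore expected to reach about 30000 nM in this assay, within 8000 nM to 120000 nM, a step of a 450-fold higher number from compound 2 to compound 4 (2.66 log units; beyond the scatter).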

Compound 4, half-maximal inhibitory concentration: 2800 nM
Compound 4: the middle estimate sits 11-fold (1.03 log units) above what was measured; measured number below the stated range.
By their numbers in this assay, from the lowest: compound 2; then compounds 3 and 4 (each within the scatter of the next); then compound 1.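

In this assay, the result shows that chain length alone matters at this position: with carboxymethyl in place of carboxy on a saturated chain carbon, five bonds along the chain from an oxygen on an aromatic ring, there is a 16-fold lower number from compound 1 to compound 4 (1.21 log units; beyond the scatter), a large change for so small an extension that compound 1 could not have revealed. The chain acid still does not match the hydroxamic acid on its ring, since 4-carboxybutyl in place of 4-(hydroxycarbamoyl)phenoxy gives a 42-fold higher number from compound 2 to compound 4 (1.63 log units; beyond the scatter), so the two kinds of end group remain clearly apart even with the better chain. No measurement at hand explains either step.

The compounds shown leave open whether a longer chain ending in a carboxylic acid would lower the number further or raise it again. They also leave open how much of the standing of compound 2 belongs to the hydroxamic acid and how much to the benzene ring that carries it, as the two change together in this step, and a hydroxamic acid on a plain saturated chain would separate them.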